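This account rests on a few compounds, and the source may have more. Where it says the series, first, only, none or still open, it means among the compounds named here.

Compounds measured so far:

Compound 1, `CC[C@H](Nc1nc(NCc2ccccn2)c2ncn(C(C)C)c2n1)C(O)C(C)(C)C` — 38000 nM
Compound 2, `CC[C@H](Nc1nc(NCc2ccccn2)c2ncn(C(C)C)c2n1)C(C)O` — 10000 nM
Compound 3, `CCC(O)[C@H](CC)Nc1nc(NCc2ccccn2)c2ncn(C(C)C)c2n1` — 21000 nM

In a functional assay on A2780 cells (Homo sapiens) for inhibition, read by sulforhodamine B assay, with a stated time of 96 h (on this read-out higher numbers stand for weaker inhibition of growth and lower numbers for stronger inhibition of growth), compound 3 stands second highest of the three numbers; its nearest neighbour is compound 1, where a 1.8-fold lower number from compound 1 to compound 3 (0.26 log units; within the scatter), and its furthest is compound 2, where a 2.1-fold higher number from compound 2 to compound 3 (0.32 log units; beyond the scatter).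

Compound 4, `CC[C@@H](Nc1nc(NCc2ccccn2)c2ncn(C(C)C)c2n1)C(C)O`, has not yet been measured. It differs from compound 3 in one place: 1-(1-hydroxyethyl)propyl in place of 1-ethyl-2-hydroxybutyl on a nitrogen on an aromatic ring. Compound 4 shares the constitution of compound 2 but differs from it at the defined stereocentre.

For the measured compounds named here, the step that bears on this change is the one between compound 2 and compound 3, the same constitutional difference read the other way, where a 2.1-fold higher number from compound 2 to compound 3 (0.32 log units; beyond the scatter) is modest and beyond the scatter. Whether the other stereocentre configuration behaves like compound 2 cannot be read from the numbers shown. The expectation is therefore a modest drop in the number, weaker than the return to compound 2 would suggest, with a wide range either side.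

Compound 4 is estimated at 15000 nM, within 5000 nM to 45000 nM, which is expected to mean a 1.4-fold lower number from compound 3 to compound 4 (0.15 log units; within the scatter).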

Compound 4, concentration for 50% growth inhibition: 15000 nM
For compound 4 middle estimate and measured number coincide at the digits printed, and the stated range covers the measured number.
By their numbers in this assay, from the lowest: compounds 2, 4, 3 and 1 (each within the scatter of the next, the first and the last beyond it).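

In this assay the change of the drawn configuration at the saturated chain carbon from S to R gives a 1.5-fold higher number from compound 2 to compound 4 (0.18 log units; within the scatter) and so leaves the two compounds unseparated on this read-out, although that comparison carries a reservation: the fact that one of compounds 2 and 4 is drawn with a defined configuration and the other without, at the place where they differ. With the R configuration, 1-(1-hydroxyethyl)propyl in place of 1-ethyl-2-hydroxybutyl gives a 1.4-fold lower number from compound 3 to compound 4 (0.15 log units; within the scatter) whereas the S pair showed a 2.1-fold higher number from compound 2 to compound 3 (0.32 log units; beyond the scatter), so the small gap seen earlier between these two side chains does not carry over to the other configuration. The separation from the 1-ethyl-2-hydroxy-3,3-dimethylbutyl group does carry over, with a 2.5-fold lower number from compound 1 to compound 4 (0.40 log units; beyond the scatter) matching the direction of a 3.8-fold lower number from compound 1 to compound 2 (0.58 log units; beyond the scatter) for the S compound.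

The compounds shown leave open how the configuration at the carbon bearing the hydroxyl group bears on the number, and whether the R configuration would make any difference in the larger side chains of compound 1 and compound 3. They also leave open what a methyl ether or an amine in place of the hydroxyl group, or a longer chain on the carbon bearing it, would do in this assay.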